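The compounds below may be only part of what the source reports. "The series", "measured", "known", "first", "only" and "open" are said of these compounds alone.

The set rests on one shared core. Compound 1 `C=C1C(=O)[C@H]2C[C@]1(O)CC1=C2[C@]2(C)CCC[C@](C)(CO)[C@H]2CC1` has no result in a functional assay on A 172 cells (Homo sapiens) for cytotoxicity, read by MTT assay, with a stated time of 24 h; a higher number here means a weaker inhibitor, a lower number a stronger inhibitor; compound 1 stands at "not determined" (no result reported). Compound 2 `C[C@@H]1C(=O)[C@H]2C[C@]1(O)CC1=C2[C@]2(C)CCC[C@](C)(CO)[C@H]2CC1` reaches only a limit in this assay, giving > 50000 nM. Compound 3 `C[C@@H]1C(=O)[C@H]2C[C@]1(O)CC1=C2[C@]2(C)CCC[C@](C)(C=O)[C@H]2CC1` likewise returns a limit, > 50000 nM. Among the measured compounds shown here, the one change among measured compounds, formyl in place of hydroxymethyl on a saturated ring carbon, gives a step that the two limits leave unreadable from compound 2 to compound 3, so no readable step exists anywhere; what is known is the limit of > 50000 nM in this assay, at which 2 of the 3 values shown sit.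

Compound 4 `C[C@@H]1C(=O)[C@H]2C[C@]1(O)CC1=C2[C@]2(C)CCC[C@@](C)(CO)[C@H]2CC1` is the unmeasured partner of compound 2. Between them, (the two compounds have the same atoms and bonds and differ only in configuration as drawn: 1 of 6 stereo elements differ; a stereocentre at a saturated ring carbon is drawn S in compound 2 and R in compound 4). For the measured compounds named here, no measured step concerns a change of configuration, and the single measured step is itself unreadable, so nothing points to a movement in either direction beyond the scatter. Compound 2 already sits at a limit in this assay, and that is the only anchor. Compound 4 is therefore expected to give about 60000 nM in this assay, in a range from 15000 nM to 250000 nM, most likely as another limit. The expected step from compound 2 to compound 4 is estimated as a step that the limit leaves unreadable from compound 2 to compound 4.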

Compound 4, half-maximal inhibitory concentration: > 50000 nM
Compound 4: no number, only a limit; the forecaster's own chance of this, stated with the estimate: 85%; the middle value is on the limit's open side.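

Compound 4, like compound 2, returns only a limit in this assay, so no step can be read between these two compounds. The compounds shown leave open whether this change of configuration, or the change from hydroxymethyl to formyl, alters the result in this assay at all.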